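The source may hold more compounds than are shown below. What is called first, only, known or untested is meant among the compounds shown, and "the series" means these compounds.

Compound 1 `COc1ccc(C(=O)c2cc(OC)c(OC)c(OC)c2)cc1NC(=O)/C=C/c1ccc(OC)c(OC)c1` and compound 2 `COc1ccc(C(=O)c2cc(OC)c(OC)c(OC)c2)cc1NC(=O)/C=C/c1ccc(F)c(F)c1` share one core and differ only in the group on a double-bonded chain carbon bound to a double-bonded chain carbon. In a functional assay on DU-145 cells (Homo sapiens) for cytotoxicity, read by MTT assay, with a stated time of 72 h (on this read-out lower numbers stand for stronger inhibition and higher numbers for weaker inhibition), compound 1 gives 10200 nM, and in this assay compound 2 gives 10200 nM. Among the compounds with values here, the step of no change at the digits printed from compound 1 to compound 2 (within the scatter) shows that this exchange left the read-out unchanged, so compound 2 stands level with compound 1 on the numbers so far. Compound 3 `COc1ccc(C(=O)c2cc(OC)c(OC)c(OC)c2)cc1NC(=O)/C=C/c1ccc([N+](=O)[O-])cc1` has not yet been measured; it differs from compound 2 by 4-nitrophenyl in place of 3,4-difluorophenyl on a double-bonded chain carbon bound to a double-bonded chain carbon. Within the data shown here, the only measured step that bears on this place, no change at the digits printed from compound 1 to compound 2 (within the scatter), stayed within the scatter. For compound 3 the expected step is therefore no change at the digits printed from compound 2 to compound 3 (within the scatter), with no movement beyond the scatter expected in this assay. Compound 3 is thus estimated at 10200 nM, with a range from 4000 nM to 26000 nM.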

Compound 3, half-maximal inhibitory concentration: 15600 nM
Compound 3: the middle estimate sits 1.5-fold (0.18 log units) below what was measured; the measured number falls inside the stated range.
By their numbers in this assay, from the lowest: compounds 1, 2 and 3 (each within the scatter of the next).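

In this assay, putting 4-nitrophenyl in place of 3,4-difluorophenyl gives a 1.5-fold higher number from compound 2 to compound 3 (0.18 log units; within the scatter) and putting it in place of 3,4-dimethoxyphenyl gives a 1.5-fold higher number from compound 1 to compound 3 (0.18 log units; within the scatter) so both new steps stay within the scatter. This place on the double-bonded chain carbon has now taken three different substituted phenyl groups, including one that brings a nitro group with its two hydrogen-bond acceptors, and the read-out does not separate any of them. Nothing given here explains this insensitivity to the change. On these data alone, what stays open is whether an amine or a carboxylic acid on the phenyl ring would move the number beyond the scatter. As far as these compounds go, it is equally open whether the unsubstituted phenyl or a saturated alkyl chain in place of the ring would do so.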